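Orexin-2 antagonists: removing the methoxy from the fused core

The compounds below may be only part of what the source reports. "The series", "measured", "known", "first", "only" and "open" are said of these compounds alone.

Compound 2 `CCc1nc(OC)c2n1CCN([C@@H](C(=O)NC)c1ccccc1)C2CCc1ccc(C(F)(F)F)cc1` is the reference point for the next step. Going by the values given here, in a functional assay on CHO cells for antagonist activity at Orexin receptor type 2 (Homo sapiens), read by FLIPR and calcium flux (on this read-out lower numbers stand for stronger inhibition and higher numbers for weaker inhibition), compound 2 gives 73 nM, the lowest of the two numbers measured so far. Its nearest neighbour is compound 1 `CCOc1nc(CC)n2c1C(CCc1ccc(C(F)(F)F)cc1)N([C@@H](C(=O)NC)c1ccccc1)CC2`, which in this assay gives 2750 nM; the difference between them is a 38-fold lower number from compound 1 to compound 2 (1.58 log units; beyond the scatter), with hydrogen in place of methyl on a saturated chain carbon bound to an oxygen on an aromatic ring.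

Compound 3 `CCc1ncc2n1CCN([C@@H](C(=O)NC)c1ccccc1)C2CCc1ccc(C(F)(F)F)cc1` takes this direction one step further: hydrogen in place of methoxy on an aromatic carbon. Among the compounds with values here, the only measured step that bears on this change is a 38-fold lower number from compound 1 to compound 2 (1.58 log units; beyond the scatter), which shows that shortening the group at this aromatic carbon brought a large gain. Whether losing the oxygen altogether keeps that gain, or costs part of it, cannot be read from a single step, so the expectation for compound 3 is a small step, a 1.4-fold higher number from compound 2 to compound 3 (0.14 log units; within the scatter), in an uncertain direction and with a wide range. In this assay compound 3 is therefore estimated at 100 nM, expected to fall between 20 nM and 600 nM.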

Compound 3, half-maximal inhibitory concentration: 194 nM
For compound 3 the middle estimate is 1.9-fold (0.29 log units) below the measured one; the measured number falls inside the stated range.
By their numbers in this assay, from the lowest: compound 2; then compound 3; then compound 1.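

At this aromatic carbon of the five-membered ring, this assay now compares hydrogen, methoxy and ethoxy, and the number does not fall steadily as the group gets smaller: taking away methoxy gives a 2.7-fold higher number from compound 2 to compound 3 (0.42 log units; beyond the scatter) and so gives back part of the earlier gain, making compound 3 the exception to the trend suggested by the first step. The oxygen-linked group is not needed to stay far ahead of compound 1, since replacing ethoxy with hydrogen still gives a 14-fold lower number from compound 1 to compound 3 (1.15 log units; beyond the scatter) and so most of the difference from compound 1 survives the loss of the whole group. No measurement to hand accounts for this order among the three groups.

The compounds shown leave open how an amine, a fluorine atom or a nitrile at this carbon would compare with methoxy, and whether a group between methoxy and ethoxy in length, or any longer chain, would behave as ethoxy does. They also leave open whether the same order among hydrogen, methoxy and ethoxy holds when the ethyl group on the same ring is replaced by another chain.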